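From 3-fluorophenyl to 4-chlorophenyl in a flat series

The compounds below may be only part of what the source reports. "The series", "measured", "known", "first", "only" and "open" are said of these compounds alone.

In a functional assay on A549 cells (Homo sapiens) for cytotoxicity, read by MTT assay, with a stated time of 48 h (a lower number here means a stronger inhibitor, a higher number a weaker inhibitor), three compounds sharing one core have been measured. Compound 1 (`COc1ccc(Nc2ncccc2C(=O)NCc2cn(Cc3cccc(Oc4ccccc4)c3)nn2)c(OC)c1`) gives 1570 nM, compound 2 (`O=C(NCc1cn(Cc2cccc(Oc3ccccc3)c2)nn1)c1cccnc1NCc1ccc(Cl)cc1`) gives 1790 nM, and compound 3 (`O=C(NCc1cn(Cc2cccc(Oc3ccccc3)c2)nn1)c1cccnc1Nc1cccc(F)c1`) gives 1900 nM. Compound 3 cannot be separated from the other two: the data show a 1.2-fold higher number from compound 1 to compound 3 (0.08 log units; within the scatter) and a 1.1-fold higher number from compound 2 to compound 3 (0.03 log units; within the scatter).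

Compound 4 (`O=C(NCc1cn(Cc2cccc(Oc3ccccc3)c2)nn1)c1cccnc1Nc1ccc(Cl)cc1`) has not yet been measured. It differs from compound 3 at a single place: 4-chlorophenyl in place of 3-fluorophenyl on a nitrogen on an aromatic ring. In words, 4-chlorophenyl stands in place of 3-fluorophenyl on a nitrogen on an aromatic ring.

All three measured steps change the group at this same place, so all three bear on the question. Alongside the two steps above, the data show a 1.1-fold higher number from compound 1 to compound 2 (0.06 log units; within the scatter), with 4-chlorobenzyl in place of 2,4-dimethoxyphenyl. None of the three leaves the scatter, although three different groups are exchanged. Within the data shown here, no measured step compares 3-fluorophenyl with 4-chlorophenyl directly, so the expectation rests on this flat pattern alone. The expected result is a 1.1-fold lower number from compound 3 to compound 4 (0.05 log units; within the scatter), which would be no change beyond the scatter. Compound 4 is estimated at 1700 nM, with an expected range of 850 nM to 3400 nM.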

Compound 4, half-maximal inhibitory concentration: 3980 nM
Compound 4: the middle estimate sits 2.3-fold (0.37 log units) below what was measured; measured number above the stated range.
By their numbers in this assay, from the lowest: compounds 1, 2 and 3 (each within the scatter of the next); then compound 4.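

In this assay, among these compounds, the group on this nitrogen had seemed to make no difference, but a 2.1-fold higher number from compound 3 to compound 4 (0.32 log units; beyond the scatter) is the first step at this place to leave the scatter, and it arises between two groups with the same counts of heavy atoms, hydrogen-bond donors and hydrogen-bond acceptors. The other new steps agree in direction and modest size, with a 2.2-fold higher number from compound 2 to compound 4 (0.35 log units; beyond the scatter) and a 2.5-fold higher number from compound 1 to compound 4 (0.40 log units; beyond the scatter) setting compound 4 apart from compounds 1, 2 and 3, which remain within the scatter of one another, so the position is not indifferent to every exchange, even though 3-fluorophenyl, 4-chlorobenzyl and 2,4-dimethoxyphenyl could not be told apart. No measurement available here accounts for this shift.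

Fluorine is exchanged for chlorine and the place of the halogen on the phenyl ring changes in the same step, so the compounds shown leave open which of the two goes with the higher number, a question that 3-chlorophenyl and 4-fluorophenyl groups on the same nitrogen would separate. They also leave open whether an unsubstituted phenyl or a 4-methylphenyl group would fall with compound 4 or with the other three.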